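The compounds below may be only part of what the source reports. "The series", "measured", "known", "first", "only" and "open" are said of these compounds alone.

In a functional assay on A549 cells (Homo sapiens) for antiproliferative activity, read by MTT assay, with a stated time of 72 h (a lower number here means a stronger inhibitor, a higher number a weaker inhibitor), compound 1 `CCNC(=O)c1cc(Oc2ccc(NC(=O)c3nn(-c4ccc(Br)cc4F)c(=O)cc3C)cc2)ccn1` gives 34500 nM, and compound 2 `CCNC(=O)c1cc(Oc2ccc(NC(=O)c3nn(-c4cccc(F)c4)c(=O)cc3C)cc2)ccn1` gives 7410 nM, the lower of these two numbers. Compound 3 `CCNC(=O)c1cc(Oc2ccc(NC(=O)c3nn(-c4cccc(C(F)(F)F)c4)c(=O)cc3C)cc2)ccn1` differs from compound 2 by trifluoromethyl in place of fluoro on an aromatic carbon. Going by the values given here, the only measured step in this part of the molecule is a 4.7-fold lower number from compound 1 to compound 2 (0.67 log units; beyond the scatter), which is modest and beyond the scatter. That step involves no trifluoromethyl, so it gives only a loose guide, and no clear direction. The expected change in this assay is small, a 1.1-fold higher number from compound 2 to compound 3 (0.03 log units; within the scatter), within the scatter. For compound 3, the estimated value is 8000 nM, with an expected range of 2500 nM to 25000 nM.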

Compound 3, half-maximal inhibitory concentration: 10000 nM
The estimate for compound 3 lay 1.3-fold (0.10 log units) below the measured number; measured number inside the range.
By their numbers in this assay, from the lowest: compounds 2 and 3 (each within the scatter of the next); then compound 1.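

In this assay, trifluoromethyl in place of fluoro on this aromatic carbon gives a 1.3-fold higher number from compound 2 to compound 3 (0.13 log units; within the scatter), so this change does not separate the two groups in this assay. The 3-(trifluoromethyl)phenyl group, like 3-fluorophenyl, stands apart from 4-bromo-2-fluorophenyl, with a 3.5-fold lower number from compound 1 to compound 3 (0.54 log units; beyond the scatter). Nothing measured here explains these numbers. The compounds shown leave open whether an amine, a methoxy group or a carboxylic acid on this carbon would move the number beyond the scatter.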